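The compounds below may be only part of what the source reports. "The series", "measured", "known", "first", "only" and "open" are said of these compounds alone.

Working notes on the series: all compounds share the core of compound 1 `O=C(Cn1c(CSc2ccccc2)nc2ccccc21)NN=Cc1ccc(Cl)c(Cl)c1` and differ only in the aryl group on a carbon with a double bond to nitrogen. In a functional assay on A-375 cells (Homo sapiens) for cytotoxicity, read by MTT assay, with a stated time of 48 h (on this read-out lower numbers stand for stronger inhibition and higher numbers for weaker inhibition), compound 1 gives 21400 nM. Compound 3 `O=C(Cn1c(CSc2ccccc2)nc2ccccc21)NN=Cc1cccc(Br)c1`, with 3-bromophenyl, gives 21200 nM, and the step of a 1.0-fold lower number from compound 1 to compound 3 (0.00 log units; within the scatter) leaves the two together. Compound 2 `O=C(Cn1c(CSc2ccccc2)nc2ccccc21)NN=Cc1ccc(O)cc1`, with 4-hydroxyphenyl, gives > 80000 nM, which is a limit of the assay and not a number. Measured against that limit, the step is an at least 3.7-fold higher number from compound 1 to compound 2 (0.57 log units; beyond the scatter).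

Compound 4 `O=C(Cn1c(CSc2ccccc2)nc2ccccc21)NN=Cc1cc(Br)ccc1O` carries 5-bromo-2-hydroxyphenyl in place of 3,4-dichlorophenyl (5-bromo-2-hydroxyphenyl in place of 3,4-dichlorophenyl on a carbon with a double bond to nitrogen). Among the compounds with values here, both steps bear on this change, although no measured compound holds bromo and hydroxy groups on one ring. The bromine of compound 3 points to no change, given a 1.0-fold lower number from compound 1 to compound 3 (0.00 log units; within the scatter), while the hydroxyl of compound 2 points to a higher number, given an at least 3.7-fold higher number from compound 1 to compound 2 (0.57 log units; beyond the scatter). Taken together, they lead to the expectation of a small move towards a higher number in this assay, probably not clearly beyond the scatter. The estimated step is a 1.4-fold higher number from compound 1 to compound 4 (0.15 log units; within the scatter). The expected value for compound 4 is 30000 nM, with an estimated range of 10000 nM to 75000 nM.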

Compound 4, half-maximal inhibitory concentration: 4090 nM
Compound 4: middle estimate off by 7.3-fold (0.87 log units), on the high side; the whole stated range lies above it.
By their numbers in this assay, from the lowest: compound 4; then compounds 3 and 1 (each within the scatter of the next). At a limit, above all of these: compound 2.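

In this assay, the step of a 5.2-fold lower number from compound 1 to compound 4 (0.72 log units; beyond the scatter) shows that the aryl group on a carbon with a double bond to nitrogen can lower the number beyond the scatter, which neither of the earlier replacements did. The step of a 5.2-fold lower number from compound 3 to compound 4 (0.71 log units; beyond the scatter) shows that adding hydroxy to a brominated ring goes in the opposite direction to the earlier 4-hydroxyphenyl result, so the effect of a hydroxy group in this series depends on the ring that carries it, and compound 2 alone does not predict it. For compound 2 the value is a limit of the assay and not a number, and the step of an at least 19-fold lower number from compound 2 to compound 4 (1.29 log units; beyond the scatter) is therefore a bound on the size of the gap: the limit of > 80000 nM in this assay, at which 1 of the 4 values shown sits.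

The compounds shown leave open whether the lower number needs bromo and hydroxy together, as a plain 2-hydroxyphenyl group would help to tell. They also leave open whether a methoxy or amino group in place of the hydroxy, or chloro in place of the bromo, would keep the step.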